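Nitro for Fluoro on the Amide Nitrogen: Compound 3

A few compounds are considered here, and "the series" means these few. Any claim that something is new, unique, unknown or untested is made for them only; others in the source may bear on it.

Compound 2 `CCCCc1nc(Cl)c(C2NC(=O)NC(C)=C2C(=O)Nc2ccc(F)cc2)[nH]1` carries a 4-fluorophenyl on the amide-type nitrogen of the shared core. In an ADME assay on Vero cells (Chlorocebus sabaeus) for cytotoxicity, read by MTT assay, with a stated time of 72 h (a lower number here means a stronger inhibitor, a higher number a weaker inhibitor), compound 2 gives > 10 ug/mL, a limit of the assay rather than a number. Compound 1 `CCCCc1nc(Cl)c(C2NC(=O)NC(C)=C2C(=O)Nc2ccccc2F)[nH]1` bears 2-fluorophenyl there; in this assay compound 1 gives > 10 ug/mL, again a limit. The step that the two limits leave unreadable from compound 1 to compound 2 is thus unreadable, and both values sit at the limit of > 10 ug/mL in this assay, at which 2 of the 2 values shown sit. Compound 3 `CCCCc1nc(Cl)c(C2NC(=O)NC(C)=C2C(=O)Nc2ccc([N+](=O)[O-])cc2)[nH]1` differs by nitro in place of fluoro on an aromatic carbon. For the measured compounds named here, no measured step bears on this change, and nothing points beyond the limit. Compound 3 is expected near 15 ug/mL, within 7 ug/mL to 40 ug/mL. The step that the limit leaves unreadable from compound 2 to compound 3 is expected to stay within the scatter.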

Compound 3, half-maximal inhibitory concentration: > 10 ug/mL
Compound 3 was reported as a limit; the forecaster's own chance of this, stated with the estimate: 70%; the middle value does not contradict the limit.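

Compound 1, compound 2 and compound 3 are all reported only as limits in this assay, so no step among them can be read: the limit of > 10 ug/mL in this assay, at which 3 of the 3 values shown sit.

The compounds shown leave open whether changing the aryl group on the amide-type nitrogen alters the value in this assay at all.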